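The source may report more compounds than this note shows. Statements on the series, on what has been measured and on what is new or still open speak of the compounds shown alone.

Working notes on the series.

Compound 1 `ClCc1cccc(Cn2cnc3ncnc(Cl)c32)c1` and compound 2 `ClCc1cccc(Cn2cnc3c(Cl)ncnc32)c1` share the same atoms joined differently; the difference between the two cores is not broken down here. In a functional assay on SNB-19 cells (Homo sapiens) for cytotoxicity, read by sulforhodamine B assay, with a stated time of 48 h (a lower number here means that less compound is tolerated, a higher number that more compound is tolerated), compound 1 gives 6760 nM. Compound 2 gives only a limit of the assay, > 100000 nM in this assay, and (the limit of > 100000 nM in this assay, at which 1 of the 3 values shown sits). Compound 3 `ClCc1cccc(Cn2cnc3c(Cl)nc(Cl)nc32)c1` carries the change chloro in place of hydrogen on an aromatic carbon on the core of compound 2, and in this assay compound 3 gives 8920 nM, so the step is an at least 11-fold lower number from compound 2 to compound 3 (1.04 log units; beyond the scatter). Since the starting value of compound 2 is a limit, only the floor of that step is known.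

Compound 4 `ClCc1cccc(Cn2cnc3nc(Cl)nc(Cl)c32)c1` is to be measured and stands to compound 1 as compound 3 stands to compound 2: the change is chloro in place of hydrogen on an aromatic carbon, the same change in the same place. For the measured compounds named here, compound 1 already sits close to compound 3, so the step from compound 1 is expected to be smaller than the one seen from compound 2, estimated as a 1.7-fold lower number from compound 1 to compound 4 (0.23 log units; within the scatter) in this assay. Compound 4 is accordingly expected at 4000 nM, within 1000 nM to 15000 nM, in this assay.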

Compound 4, concentration lethal to 50% of the cells: 5120 nM
Beside the measured number, compound 4's estimate is 1.3-fold (0.11 log units) below it; the measured number falls inside the stated range.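

In this assay, chloro in place of hydrogen on an aromatic carbon, here between two ring nitrogen atoms, gives a 1.3-fold lower number from compound 1 to compound 4 (0.12 log units; within the scatter), so on the core of compound 1 this change shows no effect beyond the scatter. The same change does not carry over at one size from one core to the other: the same change on two cores in this assay, an at least 11-fold lower number (1.04 log units; beyond the scatter) from compound 2 to compound 3 and a 1.3-fold lower number (0.12 log units; within the scatter) from compound 1 to compound 4, at least 8.4-fold (0.92 log units) apart, beyond the scatter of two such steps

Compound 2 stands at a limit of the assay, so the step from it and the gap between the two steps are known only as floors, and two cores say nothing about a third: the limit of > 100000 nM in this assay, at which 1 of the 4 values shown sits.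

As far as these compounds go, whether an amine or a methoxy group in that same place on the core of compound 1 would move the number beyond the scatter stays open. Also open, from the compounds shown here alone, is how the numbers on either core would respond to a methyl or a hydroxymethyl group in place of the chloromethyl group.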